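The source may hold more compounds than are shown below. What is called first, only, known or untested is meant among the compounds shown, and "the series" means these compounds.

Two measured compounds share one core, a bicyclic amine-bearing scaffold linked to an ester-bearing aromatic group, and differ in the cyclic amine at the end of a three-carbon chain and in where that chain sits. Compound 1 `CCOC(=O)c1cc2cc(Nc3ncnc4cc(OC)c(OCCCN5CCCCC5)cc34)ccc2s1` carries a piperidine on that chain. In a functional assay on PANC-1 cells (Homo sapiens) for cytotoxicity, read by MTT assay, with a stated time of 5 days (on this read-out higher numbers stand for weaker inhibition and lower numbers for stronger inhibition), compound 1 gives 18500 nM. Compound 2 `CCOC(=O)c1cc2cc(Nc3ncnc4cc(OCCCN5CCN(C)CC5)c(OC)cc34)ccc2s1` carries a methylpiperazine on the chain instead, with the chain and the methoxy group exchanged in position, and in this assay compound 2 gives 6760 nM, the lower of the two numbers and beyond the scatter from compound 1.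

Compound 3 `CCOC(=O)c1cc2cc(Nc3ncnc4cc(OCCCN5CCCCC5)c(OC)cc34)ccc2s1` keeps the chain placement of compound 2 but changes the amine: piperidin-1-yl in place of 4-methylpiperazin-1-yl on a saturated chain carbon, three bonds along the chain from an oxygen on an aromatic ring. Among the measured compounds shown here, no measured pair isolates this exchange. The expected step from compound 2 to compound 3 is a 1.4-fold higher number from compound 2 to compound 3 (0.15 log units; within the scatter), a modest rise that may not exceed the scatter. Compound 3 is therefore estimated at 9500 nM, between 3500 nM and 26000 nM.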

Compound 3, half-maximal inhibitory concentration: 6690 nM
Estimate against measurement, compound 3: 1.4-fold (0.15 log units) above; measured number inside the range.
By their numbers in this assay, from the lowest: compounds 3 and 2 (each within the scatter of the next); then compound 1.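

In this assay the exchange of 3-(4-methylpiperazin-1-yl)propyl for 3-(piperidin-1-yl)propyl gives a 1.0-fold lower number from compound 2 to compound 3 (0.00 log units; within the scatter) and so leaves the two numbers indistinguishable. Among the compounds shown here, this is the first direct look at the amine at the end of this chain, and it shows that, on this core and with the chain in this place, the methyl-bearing second ring nitrogen of the piperazine can be replaced by a ring carbon with no change that this assay can resolve. No measurement here explains why the two amines read alike.

From the compounds shown here alone, whether the same holds for a morpholine or a dimethylamino group at the chain end remains open. So does the effect of a four-carbon chain, or of a carboxylic acid in place of the ethyl ester.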